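This account rests on a few compounds, and the source may have more. Where it says the series, first, only, none or still open, it means among the compounds named here.

Measured compounds in this series:

Compound 1 `COc1ccc(C(=O)c2cc(OC)c(OC)c(OC)c2)cc1NC(=O)/C=C/c1cc(OC)c(OC)c(OC)c1` gives 5200 nM in a functional assay on COLO 205 cells (Homo sapiens) for cytotoxicity, read by MTT assay, with a stated time of 72 h; on this read-out lower numbers stand for stronger inhibition and higher numbers for weaker inhibition.
Compound 2 `COc1cc(/C=C/C(=O)Nc2cc(C(=O)c3cc(OC)c(OC)c(OC)c3)ccc2OC)ccc1F` gives 11800 nM in this assay.

On these two numbers compound 1 stands lowest, and its nearest neighbour is compound 2: the move from one to the other is a 2.3-fold higher number from compound 1 to compound 2 (0.36 log units; beyond the scatter). That step changes the aryl group on the double-bonded chain, not the central ring.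

Compound 3 `COc1cc(C(=O)c2cc(OC)c(OC)c(OC)c2)cc(NC(=O)/C=C/c2cc(OC)c(OC)c(OC)c2)c1OC` is not yet measured. Relative to compound 1 the change is methoxy in place of hydrogen on an aromatic carbon of the central ring, ortho to a methoxy group and meta to two large groups.

Going by the values given here, no measured step in this set touches the central ring; the only step available, from compound 1 to compound 2, alters a different part of the molecule and so gives no direct guide. The expectation therefore rests on compound 1 alone, and the step is expected to be small, in either direction, possibly within the scatter. The estimate for compound 3 in this assay is 6500 nM, in a range from 2200 nM to 19000 nM, which means an expected step of a 1.3-fold higher number from compound 1 to compound 3 (0.10 log units; within the scatter).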

Compound 3, half-maximal inhibitory concentration: 5300 nM
For compound 3 the middle estimate is 1.2-fold (0.09 log units) above the measured one; measured number inside the range.
By their numbers in this assay, from the lowest: compounds 1 and 3 (each within the scatter of the next); then compound 2.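

Adding a methoxy group on an aromatic carbon of the central ring, ortho to a methoxy group and meta to two large groups, leaves the number in this assay unchanged within the scatter (a 1.0-fold higher number from compound 1 to compound 3 (0.01 log units; within the scatter)). The earlier compounds differed only in the aryl group on the double-bonded chain, so this is the only step shown that reaches the central ring, and it shows that this hydrogen can give way to a methoxy group of 2 heavy atoms with no change that can be told from the scatter. Nothing measured here accounts for this outcome, so the result can only be recorded as it stands. Still open, as far as these compounds go, is whether an amine, a carboxylic acid or a longer chain such as propoxy at this same position would also leave the number in this assay within the scatter. Also open, from the compounds shown here alone, is whether methoxy in place of hydrogen here would give a similar result on compound 2, which carries 4-fluoro-3-methoxyphenyl on the double-bonded chain, as a single step on the core of compound 1 cannot settle that.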